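A methoxy group on the shared core of compound 2

The source may report more compounds than this note shows. Statements on the series, on what has been measured and on what is new or still open speak of the compounds shown alone.

Compound 1, `CCOC(=O)c1sc(-c2ccccc2)nc1CO`: > 100000 nM
Compound 2, `CCOC(=O)c1cnc(-c2ccccc2)s1`: > 100000 nM
Compound 3, `CCn1nnc(-c2sc(-c3ccccc3O)nc2O)n1`: 24 nM

In an assay on HEK293 cells for inhibition of transient receptor potential cation channel subfamily M member 8 (Homo sapiens), read by FLIPR, with stated times of 5 min and 3 min (a higher number here means a weaker inhibitor, a lower number a stronger inhibitor), compound 2 gives only a limit, > 100000 nM. Compound 1 likewise sits at a limit, > 100000 nM. The step that the two limits leave unreadable from compound 1 to compound 2 is therefore unreadable, as both values rest on (the limit of > 100000 nM in this assay, at which 2 of the 3 values shown sit). For the measured compounds named here, compound 3 gives 24 nM, but it differs from compound 2 in several places at once, so no single step connects the two.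

Compound 4, `CCOC(=O)c1sc(-c2ccccc2)nc1OC`, differs from compound 2 by methoxy in place of hydrogen on an aromatic carbon. No measured step bears directly on this change; the one step measured among these compounds is unreadable. Compound 4 is thus expected to remain near the limit, and the expected step is an at least 1.2-fold lower number from compound 2 to compound 4 (0.09 log units; that floor lies within the scatter). Compound 4 is estimated at 80000 nM, with a range from 15000 nM to 300000 nM.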

Compound 4, half-maximal inhibitory concentration: > 100000 nM
Compound 4: a limit, no number (the forecaster's own chance of this, stated with the estimate: 65%); at least 1.2-fold (0.09 log units) between middle value and limit.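

In this assay compound 4 gives > 100000 nM, which is a limit and not a number. Its steps from compound 1 and from compound 2 therefore cannot be read: the limit of > 100000 nM in this assay, at which 3 of the 4 values shown sit. The compounds shown leave open whether methoxy in place of hydrogen changes inhibition at all.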